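This account rests on a few compounds, and the source may have more. Where it says the series, first, only, none or still open, it means among the compounds named here.

Measured so far in an assay on isolated protein for inhibition of Fatty-acid amide hydrolase 1 (Homo sapiens); on this read-out lower numbers stand for stronger inhibition and higher numbers for weaker inhibition:
compound 1, `O=C(CCCC1CCN(C(=O)c2ccccc2)CC1)c1ncco1`: 77 nM
compound 2, `O=C(CCCC1CCN(C(=O)C2CCCCC2)CC1)c1ncco1`: 45 nM

Compound 2 gives the lower of the two numbers, but the step of a 1.7-fold lower number from compound 1 to compound 2 (0.23 log units; within the scatter) lies within the scatter, so no order between compound 1 and compound 2 can be read from these values. Both carry the same core and differ only in the group on the carbonyl carbon attached to the amide-type nitrogen in the ring.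

The next compound, compound 3, `O=C(CCCC1CCN(C(=O)CC2CCCCC2)CC1)c1ncco1`, extends the same position: cyclohexylmethyl in place of cyclohexyl on a carbonyl carbon. Going by the values given here, the one step that bears on this change is the step from compound 1 to compound 2, a change at the same carbonyl carbon, and it was within the scatter. Among the compounds with values here, nothing in the measured pair points to a step beyond the scatter for this further change, and no other step speaks to it.

Compound 3 is therefore expected to sit close to compound 2, at an estimated 45 nM, with a range from 15 nM to 140 nM. The expected step is no change at the digits printed from compound 2 to compound 3 (within the scatter).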

Compound 3, half-maximal inhibitory concentration: 100 nM
Compound 3: middle estimate off by 2.2-fold (0.35 log units), on the low side; low and high end bracket the measured number.
By their numbers in this assay, from the lowest: compounds 2, 1 and 3 (each within the scatter of the next, the first and the last beyond it).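

In this assay this position now shows a step beyond the scatter, which the exchange of phenyl for cyclohexyl did not: cyclohexylmethyl in place of cyclohexyl gives a 2.2-fold higher number from compound 2 to compound 3 (0.35 log units; beyond the scatter) and is a modest step. Cyclohexylmethyl in place of phenyl gives a 1.3-fold higher number from compound 1 to compound 3 (0.11 log units; within the scatter) and leaves compound 1 and compound 3 without an order, so the change at this carbonyl carbon reads beyond the scatter only against the cyclohexyl of compound 2. No measurement offered here accounts for the step from cyclohexyl to cyclohexylmethyl.

The compounds shown leave open whether benzyl on the same carbonyl carbon would give a step like the one from cyclohexyl to cyclohexylmethyl, and whether a longer chain such as cyclohexylethyl would continue in the same direction or return to the values of the other compounds. Also open, on these data alone, is how a smaller ring such as cyclopentyl, or a cyclohexyl ring carrying an amine or a carboxylic acid, would read at this place.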